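Iodo for Fluoro on a Smaller Ring Core

The source may report more compounds than this note shows. Statements on the series, on what has been measured and on what is new or still open speak of the compounds shown alone.

Measured compounds:
Compound 1, `COc1cc2ncnc(Nc3cccc(F)c3)c2cc1OCCCN1CCNCCNCCNCC1`: 1860 nM
Compound 2, `COc1cc2ncnc(Nc3cccc(I)c3)c2cc1OCCCN1CCNCCNCCNCC1`: 2540 nM
Compound 3, `COc1cc2ncnc(Nc3cccc(F)c3)c2cc1OCCCN1CCNCCNCC1`: 7910 nM

All three were tested in a functional assay on A-431 cells (Homo sapiens) for antiproliferative activity, read by MTT assay, with a stated time of 72 h; on this read-out lower numbers stand for stronger inhibition and higher numbers for weaker inhibition. Compound 1 gives 1860 nM in this assay, and compound 2 gives 2540 nM. The two differ in one place: iodo in place of fluoro on an aromatic carbon. That change made a step of a 1.4-fold higher number from compound 1 to compound 2 (0.14 log units; within the scatter), so the two values cannot be told apart.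

Compound 3 shares the core of compound 1 except for one change: a group of 9 heavy atoms (6 carbon, 3 nitrogen; one nine-membered non-aromatic ring with 3 hetero atoms) in place of a group of 12 heavy atoms (8 carbon, 4 nitrogen; one twelve-membered non-aromatic ring with 4 hetero atoms), on a saturated chain carbon, three bonds along the chain from an oxygen on an aromatic ring. This change made a step of a 4.3-fold higher number from compound 1 to compound 3 (0.63 log units; beyond the scatter), and compound 3 gives 7910 nM in this assay, the highest number of the three.

Compound 4, `COc1cc2ncnc(Nc3cccc(I)c3)c2cc1OCCCN1CCNCCNCC1`, has not yet been measured. It differs from compound 3 in the same way that compound 2 differs from compound 1: iodo in place of fluoro on an aromatic carbon. Because the earlier step of the same change, a 1.4-fold higher number from compound 1 to compound 2 (0.14 log units; within the scatter), stayed within the scatter, a step of about the same size is expected here, namely a 1.3-fold higher number from compound 3 to compound 4 (0.12 log units; within the scatter), starting from the value of compound 3, 7910 nM. Going by the values given here, only one earlier instance of this change is known, so the expectation rests on a single pair. Compound 4 is therefore expected to give about 10500 nM in this assay, most likely between 5000 nM and 22000 nM.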

Compound 4, half-maximal inhibitory concentration: 2220 nM
For compound 4 the middle estimate is 4.7-fold (0.67 log units) above the measured one; the whole stated range lies above it.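

In this assay, iodo in place of fluoro on the core with the nine-membered ring gave a 3.6-fold lower number from compound 3 to compound 4 (0.55 log units; beyond the scatter), so the result did not carry over from the core with the larger ring: the same change on two cores in this assay, a 1.4-fold higher number (0.14 log units; within the scatter) from compound 1 to compound 2 and a 3.6-fold lower number (0.55 log units; beyond the scatter) from compound 3 to compound 4, 4.9-fold (0.69 log units) apart, beyond the scatter of two such steps

Read the other way, the nine-membered ring in place of the larger ring gave a 1.1-fold lower number from compound 2 to compound 4 (0.06 log units; within the scatter) when iodo was present, so the weakening seen with fluoro did not appear here: the same change on two cores in this assay, a 4.3-fold higher number (0.63 log units; beyond the scatter) from compound 1 to compound 3 and a 1.1-fold lower number (0.06 log units; within the scatter) from compound 2 to compound 4, 4.9-fold (0.69 log units) apart, beyond the scatter of two such steps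

This shows that, in these four compounds, the two changes do not simply add up, and a step measured on one core is a poor guide to the same step on the other; it does not show why this happens, or whether it holds anywhere else in the series, since it rests on just two pairs in a single cell assay.

The compounds shown leave open whether chloro or bromo in place of fluoro on that aromatic carbon would behave as iodo does on the core with the nine-membered ring. They also leave open whether the same dependence on the core would remain with a longer chain carrying the ring.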